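The source may hold more compounds than are shown below. What is called first, only, known or untested is meant among the compounds shown, and "the series" means these compounds.

In an ADME assay on L929 cells (Mus musculus) for cytotoxicity, read by resazurin assay, with a stated time of 72 h (on this read-out higher numbers stand for weaker inhibition and lower numbers for stronger inhibition), compound 1 (`COCOc1cccc(C(=O)/C=C/c2ccc3c(c2)B(O)OC3)c1`) gives > 10 ug/mL as a limit of the assay and not a number. Compound 2 (`O=C(/C=C/c1ccc2c(c1)B(O)OC2)c1ccco1`) gives > 10 ug/mL as a limit as well. Compound 2 therefore has no number of its own to work from (the limit of > 10 ug/mL in this assay, at which 2 of the 2 values shown sit). Compound 3 (`O=C(/C=C/c1ccc2c(c1)B(O)OC2)c1ccc(Br)cc1`) carries 4-bromophenyl in place of furan-2-yl on a carbonyl carbon. Within the data shown here, no measured step sizes this change. The only anchor for the expectation is compound 2 at > 10 ug/mL and that reading is a limit. In this assay no shift beyond the usual scatter is expected in either direction, so the expected step is small (a step that the limit leaves unreadable from compound 2 to compound 3). Compound 3 is estimated at 12 ug/mL with an expected range from 4 ug/mL to 35 ug/mL in the same read-out.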

Compound 3, half-maximal inhibitory concentration: > 10 ug/mL
Compound 3 gave a limit, no number (the forecaster's own chance of this, stated with the estimate: 60%); the middle value lies beyond the limit too.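

No step can be read from compound 2 to compound 3, since both readings are limits and not numbers: the limit of > 10 ug/mL in this assay, at which 3 of the 3 values shown sit. The compounds shown leave open whether 4-bromophenyl and furan-2-yl differ at all on this read-out, and where any of the three truly lies beyond that limit.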